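The source may report more compounds than this note shows. Statements on the series, on what has been measured and on what is new or still open speak of the compounds shown alone.

Measured to date:
compound 1 `COc1cc(/C=C/C(=O)c2cccc(-n3cc(-c4ccccc4)[nH]c3=O)c2)ccc1O` — 4160 nM
compound 2 `O=C(/C=C/c1cccc(O)c1)c1cccc(-n2cc(-c3ccc(Cl)cc3)[nH]c2=O)c1` — 4000 nM
compound 3 `COc1ccc(-c2cn(-c3cccc(C(=O)/C=C/c4ccc(O)c(OC)c4)c3)c(=O)[nH]2)cc1` — 4250 nM

In a functional assay on Hs-578T cells (Homo sapiens) for inhibition (a higher number here means a weaker inhibitor of growth, a lower number a stronger inhibitor of growth), compound 3 gives the highest of the three numbers, though compound 1 and compound 2 lie within the scatter of it, so no order among the three can be read. Going by the values given here, the only single-place step so far, a 1.0-fold higher number from compound 1 to compound 3 (0.01 log units; within the scatter), was within the scatter. Compound 4 `COc1cc(/C=C/C(=O)c2cccc(-n3cc(-c4ccc(Cl)cc4)[nH]c3=O)c2)ccc1O` differs from compound 3 by chloro in place of methoxy on an aromatic carbon. Compound 2 carries the same chlorophenyl group on a different second ring; its value and that of compound 3 are within the scatter of each other. Nothing here points beyond the scatter in either direction, so compound 4 is expected near compound 3, with a 1.0-fold lower number from compound 3 to compound 4 (0.02 log units; within the scatter). The estimate for compound 4 is 4100 nM, range 2000 nM to 8500 nM.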

Compound 4, concentration for 50% growth inhibition: 4670 nM
Estimate against measurement, compound 4: 1.1-fold (0.06 log units) below, and the stated range covers the measured number.
By their numbers in this assay, from the lowest: compounds 2, 1, 3 and 4 (each within the scatter of the next).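

In this assay the change from 4-methoxyphenyl to 4-chlorophenyl gives (a 1.1-fold higher number from compound 3 to compound 4 (0.04 log units; within the scatter)) and chloro in place of hydrogen on the same aromatic carbon gives (a 1.1-fold higher number from compound 1 to compound 4 (0.05 log units; within the scatter)), so hydrogen, methoxy and chloro cannot be told apart at this place. With the 4-chlorophenyl group held fixed, 4-hydroxy-3-methoxyphenyl in place of 3-hydroxyphenyl gives (a 1.2-fold higher number from compound 2 to compound 4 (0.07 log units; within the scatter)), so these two groups cannot be told apart either. No evidence on the cause of these results is available.

Still open, from the compounds shown here alone, is whether an amine or a carboxylic acid at this place would move the number beyond the scatter.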